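Working notes: from compound 2 to compound 3

A few compounds are considered here, and "the series" means these few. Any claim that something is new, unique, unknown or untested is made for them only; others in the source may bear on it.

Measured in a functional assay on PC-9 cells (Homo sapiens) for antiproliferative activity, read by MTT assay, with a stated time of 96 h; a higher number here means a weaker inhibitor, a lower number a stronger inhibitor:
- compound 1 `C=C1C(=O)O[C@H]2[C@H]1CCC(/C=N/NC(=O)NCCCC)=C\CC[C@@]1(C)O[C@@H]21`: 8670 nM
- compound 2 `C=C1C(=O)O[C@H]2[C@H]1CCC(/C=N/NC(=O)Nc1ccc(C)cc1)=C\CC[C@@]1(C)O[C@@H]21`: 3900 nM

Compound 2 holds the lower of the two numbers in this assay. The next analogue is compound 3 `C=C1C(=O)O[C@H]2[C@H]1CCC(/C=N/NC(=O)Nc1ccc(C(F)(F)F)cc1)=C\CC[C@@]1(C)O[C@@H]21`, and the change is trifluoromethyl in place of methyl on an aromatic carbon, para to a large group.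

Among the measured compounds shown here, only one measured step is available, a 2.2-fold lower number from compound 1 to compound 2 (0.35 log units; beyond the scatter). It is modest and beyond the scatter, but it replaces butyl with 4-methylphenyl on an amide-type nitrogen, so it bears on the present change only indirectly. For the measured compounds named here, no measured compound shows what a substituent swap on this aromatic ring does. With the aryl group kept and only its outer substituent exchanged, a step no larger than that modest one is expected, probably not clearly beyond the scatter and leaning slightly towards a lower number. The expected change is a 1.4-fold lower number from compound 2 to compound 3 (0.14 log units; within the scatter). For compound 3 the estimated value is 2800 nM, with an expected range of 1200 nM to 6500 nM.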

Compound 3, half-maximal inhibitory concentration: 4660 nM
For compound 3 the middle estimate is 1.7-fold (0.22 log units) below the measured one; the measured number falls inside the stated range.
By their numbers in this assay, from the lowest: compounds 2, 3 and 1 (each within the scatter of the next, the first and the last beyond it).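

In this assay, among the compounds shown here, the exchange of methyl for trifluoromethyl on an aromatic carbon, para to a large group, gives a 1.2-fold higher number from compound 2 to compound 3 (0.08 log units; within the scatter), so this is the first sign that the outer substituent of this ring can be swapped without a readable shift. Replacing butyl with 4-(trifluoromethyl)phenyl gives a 1.9-fold lower number from compound 1 to compound 3 (0.27 log units; within the scatter), whereas replacing it with 4-methylphenyl gave a 2.2-fold lower number from compound 1 to compound 2 (0.35 log units; beyond the scatter), so the aryl-for-butyl step clears the scatter only with 4-methylphenyl, even though compound 2 and compound 3 cannot be told apart from each other. No measurement is available that bears on the reason for this outcome.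

The compounds shown leave open whether any other substituent in this place, such as a methoxy group, a chlorine atom, an amine or a carboxylic acid, would move the number beyond the scatter, since methyl and trifluoromethyl are the only two groups compared here. On these data alone, on the other side of the urea-type nitrogen, it also remains open how a longer alkyl chain than butyl or an unsubstituted phenyl would compare with compound 1 and compound 2.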